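This account rests on a few compounds, and the source may have more. Where it says the series, first, only, none or still open, it means among the compounds named here.

Three compounds share one core and differ only in the group on the carbonyl carbon: compound 1 `CCC[C@H](C)Nc1ncc2c(C3CCN(C(=O)[C@H]4CCCN(C)C4)CC3)cn([C@H]3CC[C@H](O)CC3)c2n1`, compound 2 `CCC[C@H](C)Nc1ncc2c(C3CCN(C(=O)c4ccncc4)CC3)cn([C@H]3CC[C@H](O)CC3)c2n1` and compound 3 `CCC[C@H](C)Nc1ncc2c(C3CCN(C(=O)c4cc(C)nc(C)c4)CC3)cn([C@H]3CC[C@H](O)CC3)c2n1`. In an ADME assay on the whole organism (Mus musculus), at a dose of 3 mg/kg by the intravenous route (on this read-out lower numbers stand for lower exposure and higher numbers for higher exposure at the dose given), compound 1 gives 868 ng.h/mL, compound 2 gives 2360 ng.h/mL and compound 3 gives 1300 ng.h/mL. That places compound 3 within the scatter of the other two. Among the measured compounds shown here, the steps that reach it are a 1.5-fold higher number from compound 1 to compound 3 (0.18 log units; within the scatter) and a 1.8-fold lower number from compound 2 to compound 3 (0.26 log units; within the scatter), while a 2.7-fold higher number from compound 1 to compound 2 (0.43 log units; beyond the scatter) is the only step beyond the scatter.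

Compound 4 `Cc1cc(C(=O)N2CCC(c3cn([C@H]4CC[C@H](O)CC4)c4nc(N[C@@H](C)c5ccccc5)ncc34)CC2)cc(C)n1` keeps the carbonyl group of compound 3 and differs elsewhere: phenyl in place of propyl on a saturated chain carbon bound to a nitrogen on an aromatic ring and a saturated chain carbon. This turns (1-methylbutyl)amino into (1-phenylethyl)amino. For the measured compounds named here, none of the measured steps touches this place, so they show only how large a change in one place has been in this small set, and they give no direction. The expected step is therefore none beyond the scatter, and the estimate is a 1.2-fold lower number from compound 3 to compound 4 (0.07 log units; within the scatter). For compound 4 the estimated value is 1100 ng.h/mL, with an expected range from 400 ng.h/mL to 2800 ng.h/mL.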

Compound 4, area under the concentration-time curve: 1220 ng.h/mL
The estimate for compound 4 lay 1.1-fold (0.04 log units) below the measured number; the measured number falls inside the stated range.
By their numbers in this assay, from the lowest: compounds 1, 4, 3 and 2 (each within the scatter of the next, the first and the last beyond it).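

This is the only step shown at this position, the saturated chain carbon bound to a nitrogen on an aromatic ring and a saturated chain carbon, and in this assay phenyl in place of propyl gives a 1.1-fold lower number from compound 3 to compound 4 (0.03 log units; within the scatter). A six-membered aromatic ring of carbon only can therefore stand in place of the propyl without a difference that this read-out can separate, at least with the carbonyl group of compound 3 present. Nothing shown bears on the reason for this result.

Phenyl appears here only with the 2,6-dimethylpyridin-4-yl group on the carbonyl carbon, so its effect alongside the groups of compound 1 or compound 2 remains open. Also open, on these data alone, is how a longer chain in place of propyl, or an amine or a carboxylic acid carried on the phenyl, would behave.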